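This account rests on a few compounds, and the source may have more. Where it says the series, first, only, none or still open, it means among the compounds named here.

Measured so far in a functional assay on the whole organism with Mus musculus as the target; on this read-out lower numbers stand for an effect already at smaller amounts and higher numbers for an effect only at larger amounts of compound

compound 1 `CN(c1ccncc1)n1cccc1` gives > 20 mg/kg as a limit
compound 2 `CCN(c1ccncc1)n1cccc1` gives > 20 mg/kg as a limit
compound 3 `c1ccc(CN(c2ccncc2)n2cccc2)cc1` gives > 20 mg/kg as a limit

Compound 1 stands at > 20 mg/kg which is a limit and not a number. Within the data shown here, the series so far shows the limit of > 20 mg/kg in this assay, at which 3 of the 3 values shown sit, and nothing more. Compound 4 `CN(c1ccncc1)n1ccc(C=O)c1` carries on the core of compound 1 the change formyl in place of hydrogen on an aromatic carbon in words formyl in place of hydrogen on an aromatic carbon. The measured steps a step that the two limits leave unreadable from compound 1 to compound 2 and a step that the two limits leave unreadable from compound 1 to compound 3 lie on a saturated chain carbon and not on an aromatic carbon. Neither gives a readable size, so no step beyond the scatter is expected in this assay and no direction can be set. The estimated step is a step that the limit leaves unreadable from compound 1 to compound 4 on this basis. Compound 4 is expected near 30 mg/kg as an estimate, with an estimated range from 12 mg/kg to 80 mg/kg and another limit as the likeliest report.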

Compound 4, dose for half-maximal effect: > 20 mg/kg
Compound 4: no number, only a limit; the forecaster's own chance of this, stated with the estimate: 80%; the middle value does not contradict the limit.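

Compound 4 gives > 20 mg/kg in this assay, which is a limit and not a number. Among these compounds, with compound 1 also at a limit, no step from compound 1 to compound 4 can be read. The compounds shown leave open what dose, if any, gives a half-maximal effect for any of them: the limit of > 20 mg/kg in this assay, at which 4 of the 4 values shown sit.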